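A few compounds are considered here, and "the series" means these few. Any claim that something is new, unique, unknown or untested is made for them only; others in the source may bear on it.

Measured in a functional assay on HepG2 cells (Homo sapiens) for cytotoxicity, read by MTT assay, with a stated time of 24 h; on this read-out lower numbers stand for stronger inhibition and higher numbers for weaker inhibition:
Compound 1 `Nc1cccn2cc(Cc3ccc(F)cc3)c(=O)nc12`: > 1000000 nM (a limit)
Compound 2 `O=c1nc2ccccn2cc1Cc1ccc(F)cc1C(F)(F)F`: 804000 nM
Compound 3 `O=c1nc2ccc(Cl)cn2cc1Cc1ccc(F)cc1`: > 1000000 nM (a limit)

Compound 3 gives no actual number and stands at the limit of > 1000000 nM in this assay, at which 2 of the 3 values shown sit. Compound 1 shares that limit. Only compound 2 returns a true number, 804000 nM.

The next compound to be tested is compound 4 `O=c1nc2ccccn2cc1Cc1ccc(F)cc1`. It differs from compound 3 in one place, with hydrogen in place of chloro on an aromatic carbon. Going by the values given here, no measured pair in this small set shows what this swap does on its own, so any forecast is tentative. Compound 2 also has no chloro, and it reads 804000 nM, so a similar reading is expected for compound 4 in this assay. No change beyond the usual scatter is expected, and so no direction is predicted. The estimated step is a number no higher from compound 3 to compound 4 (the limit leaves the size open). The assay may again report only a limit. For compound 4 the expected value is 1000000 nM, with an estimated range of 500000 nM to 2000000 nM.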

Compound 4, half-maximal inhibitory concentration: > 1000000 nM
Compound 4: a limit, no number; the forecaster's own chance of this, stated with the estimate: 60%; the middle value lies on the limit itself.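

Compound 4, which carries hydrogen where compound 3 carries chloro, gives only a limit in this assay, so its steps from compound 3 and compound 1 cannot be read, and the chloro swap has no measurable size here. Going by these compounds alone, the one readable step is an at least 1.2-fold higher number from compound 2 to compound 4 (0.09 log units; that floor lies within the scatter), with hydrogen in place of trifluoromethyl on an aromatic carbon, so these values do not establish a real difference between the two compounds. Compound 4 adds a third compound without a true number, leaving compound 2 alone with one: the limit of > 1000000 nM in this assay, at which 3 of the 4 values shown sit.

As far as these compounds go, it remains open how far compound 4 lies from compound 2, and whether trifluoromethyl matters at all. Also open, from the compounds shown here alone, is whether a different group on the aromatic carbon two atoms from the ring nitrogen, such as a methoxy group or a carboxylic acid, would give a true number.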